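The source may report more compounds than this note shows. Statements on the series, on what has been measured and on what is new or still open speak of the compounds shown alone.

Measured so far:
- compound 1, `Cc1cc(-c2ccco2)c(S(C)(=O)=O)cc1C(=O)N=C(N)N`: 16 nM in a functional assay for inhibition of sodium/hydrogen exchanger (Oryctolagus cuniculus); a higher number here means a weaker inhibitor, a lower number a stronger inhibitor
- compound 2, `Cc1c(C(=O)N=C(N)N)ccc(Oc2cccnc2)c1S(C)(=O)=O`: 2200 nM in this assay

Compound 1 holds the lowest of the two numbers recorded in this assay. Compound 2 sits far above it; the two structures differ in several places at once, so only the two values themselves are known, not any single step between them. Compound 2 does not help in reading the change considered here.

The next compound is compound 3, `Cc1cc(N2CCCC2)c(S(C)(=O)=O)cc1C(=O)N=C(N)N`. Relative to compound 1 it carries a single change: pyrrolidin-1-yl in place of furan-2-yl on an aromatic carbon. The group that leaves is one five-membered aromatic ring with one hetero atom; the group that enters is one five-membered non-aromatic ring with one hetero atom, attached through its nitrogen, at the same aromatic carbon ortho to the methylsulfonyl group. Among the compounds with values here, no pair of measured compounds shows this kind of exchange, so the direction rests on expectation alone. A modest step toward a higher number is expected, a 2.5-fold higher number from compound 1 to compound 3 (0.40 log units; beyond the scatter), close to the edge of the usual scatter. For compound 3 the estimate in this assay is 40 nM, with a range from 10 nM to 200 nM.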

Compound 3, half-maximal inhibitory concentration: 11 nM
Beside the measured number, compound 3's estimate is 3.6-fold (0.56 log units) above it, and the stated range covers the measured number.
By their numbers in this assay, from the lowest: compounds 3 and 1 (each within the scatter of the next); then compound 2.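

In this assay, pyrrolidin-1-yl in place of furan-2-yl gives a 1.5-fold lower number from compound 1 to compound 3 (0.16 log units; within the scatter), so compound 1 and compound 3 cannot be told apart at this aromatic carbon ortho to the methylsulfonyl group. Within the data shown here, for this one pair, a five-membered aromatic ring attached through carbon and a five-membered non-aromatic ring attached through nitrogen give equivalent readings, which shows that an aromatic ring is not required here to keep the number at this level; this is the first single-place comparison. No measurement available here accounts for the two groups reading alike.

Open, going by these compounds, is whether this tolerance extends beyond five-membered rings, for example to piperidin-1-yl, morpholin-4-yl, an open-chain amine such as dimethylamino, or a single chlorine atom at the same carbon. Compound 2 differs from both compound 1 and compound 3 in several places, so its steps to them cannot be read, and the contribution of its pyridin-3-yloxy group, or of the shifted arrangement of its groups, remains unresolved.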